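The compounds below may be only part of what the source reports. "The series", "measured", "known", "first", "only" and "open" are said of these compounds alone.

Compound 1 `COn1c(-c2ccc(C)cc2)c(C=O)c2cc(C#N)c(C#N)cc21` gives 74800 nM in an assay on isolated protein for inhibition of Amine oxidase [flavin-containing] B (Homo sapiens), read by fluorescence and spectrophotometry, with a stated time of 20 min; a lower number here means a stronger inhibitor, a higher number a weaker inhibitor. Compound 2 `COn1c(-c2ccccc2)c(CO)c2cc(C#N)c(C#N)cc21` reaches only a limit of the assay, reported as > 100000 nM. Compound 2 therefore stands at the limit of > 100000 nM in this assay, at which 1 of the 2 values shown sits, so no number is known for it. Compound 3 `COn1c(-c2ccc(C)cc2)c(CO)c2cc(C#N)c(C#N)cc21` differs from compound 2 by methyl in place of hydrogen on an aromatic carbon. Going by the values given here, no measured pair shows this change alone; the expected step from compound 2 to compound 3 is a step that the limit leaves unreadable from compound 2 to compound 3, in the direction of no shift beyond the usual scatter. Compound 3 is thus estimated at 120000 nM, between 50000 nM and 300000 nM, most likely again a limit.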

Compound 3, half-maximal inhibitory concentration: > 100000 nM
Compound 3 gave a limit, no number; the forecaster's own chance of this, stated with the estimate: 60%; the middle value does not contradict the limit.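

With 4-methylphenyl in place of phenyl, compound 3 gives > 100000 nM in this assay as a limit, not a number, so methyl at this position brings no readable value, and the step between the two limits cannot be read. That limit is now shared: the limit of > 100000 nM in this assay, at which 2 of the 3 values shown sit. With 4-methylphenyl held constant, hydroxymethyl in place of formyl gives an at least 1.3-fold higher number from compound 1 to compound 3 (0.12 log units; that floor lies within the scatter) as the only readable comparison, so no firm loss is shown. On these data alone, how far this step truly reaches stays open. So does whether an amine or a carboxylic acid in place of hydroxymethyl would give a measurable number.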